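A few compounds are considered here, and "the series" means these few. Any claim that something is new, unique, unknown or untested is made for them only; others in the source may bear on it.

The series rests on a functional assay on CHO-K1 cells for agonist activity at Glucose-dependent insulinotropic receptor (Homo sapiens), read by a luciferase reporter, with a stated time of 5 h; a higher number here means that more compound is needed for the effect, a lower number that less compound is needed. Compound 1 `CC(C)(C)OC(=O)N1CCC(Oc2ncnc3c2CCN3c2ccc(S(C)(=O)=O)cc2F)CC1` gives 20 nM in this assay. Within the data shown here, compound 2 `Cc1nc(OC2CCN(C(=O)OC(C)(C)C)CC2)c2c(n1)N(c1ccc(S(C)(=O)=O)cc1F)CC2` gives 126 nM in this assay, and the one measured step, a 6.3-fold higher number from compound 1 to compound 2 (0.80 log units; beyond the scatter), places compound 2 at the higher of the two numbers seen so far, with compound 1 as its only neighbour.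

Compound 3 `Cc1nc(OC2CCN(c3nc(C(C)C)no3)CC2)c2c(n1)N(c1ccc(S(C)(=O)=O)cc1F)CC2` is not yet measured. It differs from compound 2 in one place: 3-isopropyl-1,2,4-oxadiazol-5-yl in place of tert-butoxycarbonyl on an amine nitrogen in a ring. Among the measured compounds shown here, no measured step touches this position; the only step known, a 6.3-fold higher number from compound 1 to compound 2 (0.80 log units; beyond the scatter), concerns a methyl on an aromatic carbon and says nothing about what the amine nitrogen of the six-membered ring will tolerate. The expectation for compound 3 therefore has to lean on the value of compound 2 itself, with wide uncertainty in both directions. On that basis compound 3 is expected to give about 100 nM in this assay, within a range from 25 nM to 400 nM. The expected step, a 1.3-fold lower number from compound 2 to compound 3 (0.10 log units; within the scatter), is thus estimated to be none beyond the usual scatter.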

Compound 3, half-maximal effective concentration: 251 nM
Beside the measured number, compound 3's estimate is 2.5-fold (0.40 log units) below it; low and high end bracket the measured number.
By their numbers in this assay, from the lowest: compound 1; then compounds 2 and 3 (each within the scatter of the next).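

In this assay, among these compounds, the change at this position reads a 2.0-fold higher number from compound 2 to compound 3 (0.30 log units; within the scatter), the first measured step at the amine nitrogen in the six-membered non-aromatic ring. It shows that this nitrogen can carry either of two quite different groups with no difference beyond the scatter: tert-butoxycarbonyl, which has no ring, and 3-isopropyl-1,2,4-oxadiazol-5-yl, which brings a five-membered aromatic ring with 3 hetero atoms. Activity in this assay therefore does not depend on keeping the tert-butoxycarbonyl group, which compounds 1 and 2, both carrying it, could not show; no measurement given here accounts for the two groups reading alike.

The compounds shown leave open whether other groups on this nitrogen, such as a pyrimidine ring, an acetyl group or a plain hydrogen, would read the same, and whether the isopropyl on the oxadiazole could give way to a methyl or a cyclopropyl. They also leave open how the 3-isopropyl-1,2,4-oxadiazol-5-yl group would read on the core of compound 1, which has hydrogen in place of the methyl on the aromatic carbon.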